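Removing the carbamate from the amine side chain

The compounds below may be only part of what the source reports. "The series", "measured", "known", "first", "only" and "open" are said of these compounds alone.

Measured so far:
Compound 2, `CC(C)(C)OC(=O)NCCNC(=O)CN1CN(c2ccccc2)C2(CCN(C(=O)c3ccc(C(C)(C)C)cc3)CC2)C1=O`: 10900 nM
Compound 3, `CC(C)(C)OC(=O)NCCNC(=O)CN1CN(c2ccccc2)C2(CCN(C(=O)c3ccc(C4CCCCC4)cc3)CC2)C1=O`: 5500 nM
Compound 1, `CCc1nn(CC)c(C2CCN(C(=O)CN3CN(c4ccccc4)C4(CCN(C(=O)c5ccc(C6CCCCC6)cc5)CC4)C3=O)CC2)c1C`: "not determined" (no result reported)

In an assay on HEK293 cells for displacement of a labelled ligand from NPC1-like intracellular cholesterol transporter 1 (Homo sapiens) (on this read-out higher numbers stand for weaker inhibition and lower numbers for stronger inhibition), compound 2 gives 10900 nM, the highest of the two numbers recorded. Among the measured compounds shown here, its only neighbour with a number is compound 3, and the single measured step, a 2.0-fold lower number from compound 2 to compound 3 (0.30 log units; within the scatter), is cyclohexyl in place of tert-butyl on an aromatic carbon; it lies within the scatter. Compound 1 carries no result in this assay.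

Compound 4, `CC(C)(C)c1ccc(C(=O)N2CCC3(CC2)C(=O)N(CC(=O)NCCN)CN3c2ccccc2)cc1`, is the next entry. Relative to compound 2 the change is hydrogen in place of tert-butoxycarbonyl on an amine nitrogen. For the measured compounds named here, no measured step bears on this nitrogen: the one step known concerns the aromatic substituent, stays within the scatter, and gives no guidance on what the amine truncation will do. The expectation is therefore a step of no more than the scatter in either direction, a 1.4-fold lower number from compound 2 to compound 4 (0.13 log units; within the scatter), and compound 4 is estimated at 8000 nM, with a range of 2500 nM to 30000 nM.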

Compound 4, half-maximal inhibitory concentration: 7000 nM
Estimate against measurement, compound 4: 1.1-fold (0.06 log units) above; measured number inside the range.
By their numbers in this assay, from the lowest: compounds 3, 4 and 2 (each within the scatter of the next).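

In this assay, hydrogen in place of tert-butoxycarbonyl on the amine nitrogen of the side chain gives a 1.6-fold lower number from compound 2 to compound 4 (0.19 log units; within the scatter) and so stays within the scatter. The step from compound 2 to compound 3 concerned only the aromatic substituent, whereas this one shows that, with tert-butyl on the aromatic ring, the whole tert-butoxycarbonyl group can give way to the free 2-aminoethyl chain without a change beyond the scatter. Nothing measured here accounts for the size of this step.

Whether the free amine reads the same alongside cyclohexyl stays open, as no compound shown pairs the 2-aminoethyl chain with that group. Also open, on these data alone, is what an acetyl group on this nitrogen, a carboxylic acid at the chain end or a longer chain would do.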